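The source may hold more compounds than are shown below. What is called first, only, known or untested is meant among the compounds shown, and "the series" means these compounds.

Two tetrahalogenated compounds of a shared core have been tested in a functional assay on the whole organism (serum, strain Swiss albino) with Rattus norvegicus as the target, read by spectrophotometry, with a stated time of 14 days, at a dose of 10 mg/kg by the oral route; a lower number here means less inhibition, a higher number more inhibition at the dose given (going by the name of the read-out). Compound 1 `O=C1c2c(Cl)c(Cl)c(Cl)c(Cl)c2C(=O)N1Cc1ccccn1` gives 47% in this assay. Compound 2 `O=C1c2c(Br)c(Br)c(Br)c(Br)c2C(=O)N1Cc1ccccn1` gives 54% in this assay. Of the two numbers, that of compound 2 is the higher one, but the gap to compound 1 lies within the usual scatter, so the two values are read as equal.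

Compound 3 `O=C1c2c(Br)c(Br)c(Br)c(Br)c2C(=O)N1c1ccncc1` is not yet measured in this assay. It differs from compound 2 in one place: pyridin-4-yl in place of (pyridin-2-yl)methyl on an amide-type nitrogen in a ring

Among the measured compounds shown here, no measured pair shows what such a change does to the numbers here, so the expectation rests on the two values alone. The step from compound 2 to compound 3 in this assay is expected to be small, with no change beyond the scatter, and the estimate for compound 3 is 50%, expected to fall between 35% and 65%, a step of a number 4 percentage points lower from compound 2 to compound 3 (within the scatter).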

Compound 3, a percentage reported as inhibition, in the whole organism at one dose (the size of the read-out at that dose, not a potency): 13%
Beside the measured number, compound 3's estimate is 37 percentage points above it; measured number outside the range, below it.
By their numbers in this assay, from the lowest: compound 3; then compounds 1 and 2 (each within the scatter of the next).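

The two earlier compounds both carry (pyridin-2-yl)methyl on the amide-type nitrogen in a ring, so they could not show whether this position matters. In this assay, it clearly does: putting pyridin-4-yl there gives a large fall in inhibition at the dose given (a number 41 percentage points lower from compound 2 to compound 3 (beyond the scatter)). The groups that leave and enter each hold one six-membered aromatic ring with one hetero atom, so a similar ring at this position does not by itself keep the read-out, and nothing shown explains the drop.

This single step changes both the methyl link and the pyridine attachment point, so the two changes cannot be separated. A (pyridin-4-yl)methyl group or a pyridin-2-yl group on the same nitrogen would help to tell them apart, and a longer chain such as 2-(pyridin-2-yl)ethyl would test the link's length.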